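A few compounds are considered here, and "the series" means these few. Any claim that something is new, unique, unknown or untested is made for them only; others in the source may bear on it.

Three compounds have numbers in a functional assay on MCF7 cells (Homo sapiens) for cytotoxicity, read by MTT assay, with a stated time of 48 h; a lower number here means a stronger inhibitor of growth, a higher number a weaker inhibitor of growth. Compound 1 `C=CCn1c(C(F)(F)F)nc2cc(Cl)c(Cl)cc21` gives 87000 nM and compound 2 `FC(F)(F)c1nc2cc(Cl)c(Cl)cc2n1CC1CC1` gives 60200 nM. Compound 3 `Clc1cc2ncn(C3CCCC3)c2cc1Cl` gives 42000 nM, which is within the scatter of compound 2 and lower, beyond the scatter, than compound 1.

Compound 4 `FC(F)(F)c1nc2cc(Cl)c(Cl)cc2n1C1CCCC1` has yet to be measured. It puts trifluoromethyl in place of hydrogen on an aromatic carbon of compound 3: trifluoromethyl in place of hydrogen on an aromatic carbon.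

Within the data shown here, no measured pair shows this swap directly. Among the measured compounds shown here, the only measured step, a 1.4-fold lower number from compound 1 to compound 2 (0.16 log units; within the scatter), is cyclopropyl in place of vinyl on a saturated chain carbon bound to an aromatic nitrogen, so it concerns a different place and stays within the scatter. For the measured compounds named here, the only indirect guide is that compound 1 at 87000 nM and compound 2 at 60200 nM already carry trifluoromethyl, though with other groups on the nitrogen. A slightly higher number is therefore possible, but no change beyond the scatter is expected in this assay.

The expected change is a 1.2-fold higher number from compound 3 to compound 4 (0.08 log units; within the scatter). For compound 4 the estimated value is 50000 nM, with an expected range from 20000 nM to 120000 nM.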

Compound 4, concentration for 50% growth inhibition: 21000 nM
For compound 4 the middle estimate is 2.4-fold (0.38 log units) above the measured one; low and high end bracket the measured number.
By their numbers in this assay, from the lowest: compounds 4, 3, 2 and 1 (each within the scatter of the next, the first and the last beyond it).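

Among these compounds, this is the first direct reading of trifluoromethyl in place of hydrogen on the aromatic carbon between two ring nitrogen atoms, and in this assay the swap stays within the scatter (a 2.0-fold lower number from compound 3 to compound 4 (0.30 log units; within the scatter)), so no effect can be claimed for it with a cyclopentyl group on the neighbouring ring atom. With trifluoromethyl held fixed, the group on the aromatic nitrogen now gives modest steps beyond the scatter (a 2.9-fold lower number from compound 2 to compound 4 (0.46 log units; beyond the scatter); a 4.1-fold lower number from compound 1 to compound 4 (0.62 log units; beyond the scatter)), which the step from compound 1 to compound 2 did not. No measurement at hand explains these steps.

As far as these compounds go, whether a methyl group or an amine on this same carbon would move the number beyond the scatter remains open. So does how a longer chain or a cyclohexyl group on the aromatic nitrogen would compare with cyclopentyl.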